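The source may hold more compounds than are shown below. What is called first, only, known or untested is meant among the compounds shown, and "the series" means these compounds.

Measured compounds in a functional assay, with a stated time of 150 min, tested at 20 ug/mL; on this read-out lower numbers stand for a weaker effect and higher numbers for a stronger effect at the one concentration tested:

Compound 1, `COC(=O)c1c(Nc2ccccc2)sc(C(=O)c2ccc(OC)cc2)c1C`, gives 32.4%.
Compound 2, `COC(=O)c1c(Nc2ccc(F)cc2)sc(C(=O)c2ccc(OC)cc2)c1C`, gives 18.2%.
Compound 3, `COC(=O)c1c(Nc2ccccc2)sc(C(=O)c2ccc(C)cc2)c1C`, gives 6.06%.

Compound 3 stands lowest of these three numbers: compound 2 lies nearest, and compound 1 furthest above it, both gaps beyond the usual scatter. Compound 4, `COC(=O)c1c(Nc2ccc(F)cc2)sc(C(=O)c2ccc(C)cc2)c1C`, has not yet been measured. It differs from compound 3 in one place: fluoro in place of hydrogen on an aromatic carbon.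

The same change has been seen once before, between compound 1 and compound 2, which share the methoxy group rather than the methyl: there the read-out fell, a number 14.2 percentage points lower from compound 1 to compound 2 (beyond the scatter). Among the compounds with values here, that single step is the only direct guide. Compound 3 already sits close to the bottom of the scale, so a fall of the same size cannot be repeated in full; a small downward step, or none beyond the scatter, is expected, written as a number 3.1 percentage points lower from compound 3 to compound 4 (within the scatter).

Compound 4 is therefore estimated at 3%, within a range from 0% to 14%.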

Compound 4, a percentage reported as activity, at one concentration (the size of the read-out at that concentration, not a potency): "not active" (no number reported)
Compound 4 has no reported number here, so the estimate cannot be set against anything.
By their numbers in this assay, from the lowest: compound 3; then compound 2; then compound 1.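

Within the data shown here, compound 4 is reported as "not active" with no number, so no step from compound 3 to compound 4 can be read. The compounds shown leave open whether fluoro in place of hydrogen changes the read-out when methyl replaces methoxy. No available evidence bears on this result.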